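The compounds below may be only part of what the source reports. "The series", "measured", "known", "first", "only" and "open" are said of these compounds alone.

Compound 1 `O=C(O)c1ccc(CCCN2C(=O)CC[C@@H]2CCC(O)Cc2ccccc2)s1`: 690 nM
Compound 2 `O=C(O)c1ccc(CCCN2C(=O)CC[C@@H]2CCC(O)Cc2ccc(Cl)cc2)s1`: 86 nM

In an assay on HEK293 cells for binding affinity to prostaglandin E2 receptor EP2 subtype (Rattus norvegicus) (a higher number here means a weaker inhibitor, a lower number a stronger inhibitor), compound 2 stands at the lower of the two numbers, the stronger of the pair. Compound 3 `CCc1ccc(CC(O)CC[C@H]2CCC(=O)N2CCCc2ccc(C(=O)O)s2)cc1` differs from compound 2 by ethyl in place of chloro on an aromatic carbon. Going by the values given here, the only measured step, an 8.0-fold lower number from compound 1 to compound 2 (0.90 log units; beyond the scatter), concerns a chloro entering where hydrogen stood; no measured step swaps chloro for ethyl, so it bears only loosely on this change. Both chloro and ethyl occupy the same position, so a step within the scatter or slightly toward a higher number is expected. Compound 3 is expected near 150 nM, between 50 nM and 500 nM. That corresponds to an expected 1.7-fold higher number from compound 2 to compound 3 (0.24 log units; within the scatter).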

Compound 3, half-maximal inhibitory concentration: 1200 nM
For compound 3 the middle estimate is 8.0-fold (0.90 log units) below the measured one, outside the stated range (above it).
By their numbers in this assay, from the lowest: compound 2; then compounds 1 and 3 (each within the scatter of the next).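

In this assay, the lower number seen with chloro does not extend to every group at this position: ethyl in place of chloro gives a 14-fold higher number from compound 2 to compound 3 (1.14 log units; beyond the scatter) and so loses the whole of that step. Ethyl in place of hydrogen gives a 1.7-fold higher number from compound 1 to compound 3 (0.24 log units; within the scatter), so here filling the position with ethyl offers no measurable change from leaving it with hydrogen. No measured evidence explains why chloro and ethyl part ways. Still open, as far as these compounds go, is how fluoro, methoxy or a longer chain such as propyl would behave at this position.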